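Notes on a pyrimidine-acetamide series: paw edema inhibition

The compounds below may be only part of what the source reports. "The series", "measured", "known", "first", "only" and "open" are said of these compounds alone.

Measured compounds:
compound 1, `N#Cc1c(Nc2ccc(O)cc2)nc(SCC(=O)Nn2c(COc3ccc(Cl)cc3Cl)nc3ccccc3c2=O)nc1-c1ccccc1`, 72.7%
compound 2, `N#Cc1c(Nc2ccc(O)cc2)nc(SCC(=O)Nn2c(COc3ccc(Cl)cc3Cl)nc3ccccc3c2=O)nc1-c1ccc(Cl)cc1`, 90.9%
compound 3, `N#Cc1c(Nc2ccc(Cl)cc2)nc(SCC(=O)Nn2c(COc3ccc(Cl)cc3Cl)nc3ccccc3c2=O)nc1-c1ccc(O)cc1`, 72.7%

In a functional assay on the whole organism (strain albino) for inhibition, with Rattus norvegicus as the target, read by paw edema, with a stated time of 1 h, at a dose of 100 mg/kg by the oral route (on this read-out higher numbers stand for more inhibition at the one dose given (going by the name of the read-out) and lower numbers for less inhibition), compound 3 gives 72.7%. It stands level with compound 1 at the digits printed, the two together the lowest of the three numbers; compound 2 stands furthest from it, giving 90.9%. For the measured compounds named here, the only step measured within one change is a number 18.2 percentage points higher from compound 1 to compound 2 (beyond the scatter), a modest rise beyond the scatter.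

Compound 4, `N#Cc1c(Nc2ccc(O)cc2)nc(SCC(=O)Nn2c(COc3ccc(Cl)cc3Cl)nc3ccccc3c2=O)nc1-c1ccc(O)cc1`, has not yet been measured in this assay. It differs from compound 3 by hydroxy in place of chloro on an aromatic carbon, that is, (4-chlorophenyl)amino to (4-hydroxyphenyl)amino. Going by the values given here, no measured step touches this position: the one measured step, from compound 1 to compound 2, changes a different ring, and compound 1 and compound 3, which carry hydroxy and chloro at the two positions in swapped order, give the same number. That swap gives no basis for a direction, so no step beyond the scatter is expected.

Compound 4 is estimated to give 70%, in a range from 55% to 85%. The step this means, a number 2.7 percentage points lower from compound 3 to compound 4 (within the scatter), is expected to lie within the scatter.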

Compound 4, a percentage reported as inhibition, in the whole organism at one dose (the size of the read-out at that dose, not a potency): 86.4%
Estimate against measurement, compound 4: 16.4 percentage points below; the whole stated range lies below it.
By their numbers in this assay, from the lowest: compounds 1 and 3 (each within the scatter of the next); then compounds 4 and 2 (each within the scatter of the next).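

At the (4-chlorophenyl)amino position, hydroxy in place of chloro gives a number 13.7 percentage points higher from compound 3 to compound 4 (beyond the scatter) in this assay, the first measured sign that this position matters. On the other aromatic ring, with (4-hydroxyphenyl)amino held fixed, hydroxy in place of hydrogen gives a number 13.7 percentage points higher from compound 1 to compound 4 (beyond the scatter), whereas hydroxy in place of chloro gives a number 4.5 percentage points lower from compound 2 to compound 4 (within the scatter), so either substituent there reads apart from hydrogen but the two do not read apart from each other. Nothing on hand gives a cause for these steps.

The compounds shown leave open whether the change at the amino-linked ring holds with chloro or hydrogen on the other ring. They also leave open how a methoxy group or an amine would read in place of hydroxy on either ring.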